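Trifluoromethyl for methyl on a methylsulfonyl aniline core

This account rests on a few compounds, and the source may have more. Where it says the series, first, only, none or still open, it means among the compounds named here.

Compound 1 `CSc1ccc(C)cc1NCC1=NCCN1` carries a methylsulfanyl group and, in a functional assay for agonist activity at Alpha-1D adrenergic receptor (Homo sapiens) (a higher number here means that more compound is needed for the effect, a lower number that less compound is needed), compound 1 gives 0.912 nM. Compound 2 `Cc1ccc(S(C)(=O)=O)c(NCC2=NCCN2)c1` has a methylsulfonyl group in its place. In this assay compound 2 gives only a limit, < 2000 nM. The change from methylsulfanyl to methylsulfonyl therefore yields a step that the limit leaves unreadable from compound 1 to compound 2, which cannot be sized because the limit of < 2000 nM in this assay, at which 1 of the 3 values shown sits, hides its end. Compound 3 `CC(C)S(=O)(=O)c1ccccc1NCC1=NCCN1`, with an isopropylsulfonyl group on the same core, in this assay also gives only a limit, < 5020 nM, and this rests on (the limit of < 5020 nM in this assay, at which 1 of the 3 values shown sits). So compound 2 stands on a limit alone, with one further limit beside it and a single numeric value, that of compound 1, in the whole set.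

Compound 4 `CS(=O)(=O)c1ccc(C(F)(F)F)cc1NCC1=NCCN1` differs from compound 2 by trifluoromethyl in place of methyl on an aromatic carbon. For the measured compounds named here, no measured step bears on this exchange: the only step in the set, from a methylsulfanyl to a methylsulfonyl group, is unreadable, and no pair shows a methyl against a trifluoromethyl. With nothing to point in either direction, the step from compound 2 to compound 4 in this assay is expected to be a number no lower from compound 2 to compound 4 (the limit leaves the size open), that is, none beyond the usual scatter. Compound 4 is therefore estimated at 2000 nM in this assay, within 200 nM to 20000 nM, and most likely again reported only as a limit.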

Compound 4, half-maximal effective concentration: < 100000 nM
Compound 4: only a limit was reported; the forecaster's own chance of this, stated with the estimate: 65%; the middle value does not contradict the limit.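

In this assay, for the compounds shown here, compound 4 gives only a limit, < 100000 nM, and compound 2 also stands on a limit, so no step between compound 2 and compound 4 can be read. The compounds shown leave open how large an effect trifluoromethyl in place of methyl has on the shared core in this assay.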